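From hydroxy to methoxy: compound 2 to compound 3

The source may report more compounds than this note shows. Statements on the series, on what has been measured and on what is new or still open speak of the compounds shown alone.

Measured in a functional assay on PANC-1 cells (Homo sapiens) for cytotoxicity, read by fluorescence, with a stated time of 24 h; a lower number here means a stronger inhibitor, a higher number a weaker inhibitor:
- compound 1 `CC(C)=CCC/C(C)=C/Cc1c(CCC(=O)c2ccc(O)cc2O)ccc(O)c1O` gives 42900 nM
- compound 2 `C/C(=C\Cc1c(CCC(=O)c2ccc(O)cc2O)ccc(O)c1O)CCCC(C)(C)O` gives > 75000 nM (a limit)

Compound 2 stands at > 75000 nM, which is a limit of the assay and not a number. Compound 3 `COC(C)(C)CCC/C(C)=C/Cc1c(CCC(=O)c2ccc(O)cc2O)ccc(O)c1O` is its methyl ether, hydroxy to methoxy, with methyl in place of hydrogen on an oxygen on a saturated carbon. Within the data shown here, the only measured step that bears on this change is an at least 1.7-fold higher number from compound 1 to compound 2 (0.24 log units; that floor lies within the scatter), and that step is only a floor. Among the measured compounds shown here, compound 1 at 42900 nM holds the sole numeric value, so a small shift towards a lower number in this assay is expected, possibly no larger than the scatter. The expected change is an at least 1.2-fold lower number from compound 2 to compound 3 (0.09 log units; that floor lies within the scatter). For compound 3 the estimated value is 60000 nM, within an expected range of 25000 nM to 120000 nM.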

Compound 3, half-maximal inhibitory concentration: > 75000 nM
Compound 3 ended at the assay's limit; the forecaster's own chance of this, stated with the estimate: 45%; middle value at least 1.2-fold (0.09 log units) from the limit.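

In this assay compound 3 gives > 75000 nM, which is a limit of the assay and not a number. Methyl in place of hydrogen on the oxygen thus puts a second compound at that limit, and the step between compound 2 and compound 3 cannot be read: the limit of > 75000 nM in this assay, at which 2 of the 3 values shown sit.

The one step that can be read is an at least 1.7-fold higher number from compound 1 to compound 3 (0.24 log units; that floor lies within the scatter); the 2-methoxy-2-methylpropyl group is therefore not shown to separate from the 2-methylprop-1-en-1-yl group.

As far as these compounds go, whether hydroxy and methoxy differ at all at this position stays open, as does the true size of either step from compound 1. An amine or a carboxylic acid at this chain end, or a longer chain, remains untested among the compounds shown, so it is open whether any of them would give a numeric value in this assay.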